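Nitro replacing the ester on the biaryl series

The compounds below may be only part of what the source reports. "The series", "measured", "known", "first", "only" and "open" are said of these compounds alone.

Measured so far:
compound 1 `CCOc1ccc(-c2cccc(S(=O)(=O)NC)c2)cc1`: 47%
compound 2 `CCOc1ccc(-c2cccc(C(=O)O)c2)cc1`: 23%
compound 3 `CCOc1ccc(-c2cccc(C(=O)OCCOC)c2)cc1`: 89%

In an assay on COS-7 cells for inhibition of patatin-like phospholipase domain-containing protein 2 (Mus musculus), tested at 200 uM (a higher number here means more inhibition at the concentration tested (going by the name of the read-out), a lower number less inhibition), compound 3 stands highest of the three numbers shown; its nearest neighbour is compound 1 and the furthest is compound 2. The two steps leading to compound 3 are both large: a number 42 percentage points higher from compound 1 to compound 3 (beyond the scatter) and a number 66 percentage points higher from compound 2 to compound 3 (beyond the scatter). The smaller step of a number 24 percentage points lower from compound 1 to compound 2 (beyond the scatter) is modest.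

Compound 4 `CCOc1ccc(-c2cccc([N+](=O)[O-])c2)cc1` differs from compound 3 by nitro in place of (2-methoxyethoxy)carbonyl on an aromatic carbon. Within the data shown here, the steps that bear on it are those into compound 3, since each swaps the group at the same place; both were large and in both the number is higher with the (2-methoxyethoxy)carbonyl group than with a smaller substituent. Compound 4 carries the smallest group of the four at that place, so a large step downward from compound 3 is expected in this assay, a number 54 percentage points lower from compound 3 to compound 4 (beyond the scatter), landing near the range covered by compound 1 and compound 2. Compound 4 is therefore estimated at 35%, with the likely range 10% to 65%.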

Compound 4, a percentage reported as inhibition, at one concentration (the size of the read-out at that concentration, not a potency): 35%
Compound 4: the middle estimate sits on the measured number at the digits printed; the measured number falls inside the stated range.
By their numbers in this assay, from the lowest: compound 2; then compound 4; then compound 1; then compound 3.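

In this assay, the step of a number 54 percentage points lower from compound 3 to compound 4 (beyond the scatter) shows that a group with no hydrogen-bond donors at this place does not by itself keep the number of compound 3, as (2-methoxyethoxy)carbonyl and nitro both count none. Nitro also falls among the lower groups, with a number 12 percentage points higher from compound 2 to compound 4 (beyond the scatter) and a number 12 percentage points lower from compound 1 to compound 4 (beyond the scatter), so carboxy, methylsulfamoyl and nitro all remain well short of the (2-methoxyethoxy)carbonyl group. Nothing available here accounts for these differences.

Still open, as far as these compounds go, is whether the high number of compound 3 goes with the carbonyl or with the 2-methoxyethyl chain. A methyl ester or a 2-methoxyethyl amide at this place would separate the two, and each figure here is a single-concentration reading, not a potency.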